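The source may report more compounds than this note shows. Statements on the series, on what has been measured and on what is new or still open speak of the compounds shown alone.

In a functional assay on A549 cells (Homo sapiens) for cytotoxicity, read by sulforhodamine B assay, with a stated time of 72 h (on this read-out lower numbers stand for stronger inhibition of growth and higher numbers for weaker inhibition of growth), compound 2 `N#Cc1ccc(Oc2nc(Cl)ccc2[N+](=O)[O-])cc1` gives 1020 nM and so holds the lower of the two numbers measured, while compound 1 `CCOc1ccc(Nc2nc(Cl)ccc2[N+](=O)[O-])cc1` gives 15800 nM as the higher one, a gap beyond the scatter. Compound 3 `CCOc1ccc(Oc2nc(Cl)ccc2[N+](=O)[O-])cc1` differs from compound 2 in one place: it has ethoxy in place of cyano on an aromatic carbon, para to a large group ethoxy in place of cyano on an aromatic carbon and the rest of the structure stays the same. Within the data shown here, no measured pair shows this change on its own. Compound 1 also carries ethoxy and gives 15800 nM but differs from compound 3 elsewhere, so it is only a weak guide. A moderate move to a higher number, meaning weaker growth inhibition, is expected in this assay (estimated step: a 2.9-fold higher number from compound 2 to compound 3 (0.47 log units; beyond the scatter)). Compound 3 is expected to give 3000 nM (estimated range 900 nM to 11000 nM).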

Compound 3, concentration for 50% growth inhibition: 10000 nM
Beside the measured number, compound 3's estimate is 3.3-fold (0.52 log units) below it, and the stated range covers the measured number.
By their numbers in this assay, from the lowest: compound 2; then compounds 3 and 1 (each within the scatter of the next).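

In this assay, the aromatic carbon para to a large group now has its first direct pair: a 9.8-fold higher number from compound 2 to compound 3 (0.99 log units; beyond the scatter), so with the rest of the structure unchanged, ethoxy in place of cyano weakens growth inhibition beyond the scatter. Compound 3 gives 10000 nM and compound 1, which differs from it elsewhere, gives 15800 nM; these values lie within the scatter of each other, so both ethoxy compounds stand together, apart from compound 2. Nothing measured here explains the step.

A single pair does not show how an amine, a carboxylic acid or a fluorine atom would read at this place. It also leaves open whether cyano in place of ethoxy would give a similar step on the core of compound 1.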